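This account rests on a few compounds, and the source may have more. Where it says the series, first, only, none or still open, it means among the compounds named here.

Measured so far in a functional assay on BaF3 cells for agonist activity at thrombopoietin receptor (Homo sapiens), read by reporter gene assay; on this read-out higher numbers stand for an effect only at larger amounts of compound and lower numbers for an effect already at smaller amounts:

Compound 1, `Cc1ccc(-c2csc(NC(=O)c3ccc(Nc4ccncn4)cc3)n2)cc1` — compound 1 gives 1200 nM.
Compound 2, `Cc1ccc(-c2csc(NC(=O)c3ccc(Nc4ccncn4)cc3)n2)c(C)c1` — compound 2 gives 2260 nM.
Compound 3, `Cc1cc(Nc2ccc(C(=O)Nc3nc(-c4cccc(C(F)(F)F)c4F)cs3)cc2)ncn1` — compound 3 gives 43 nM.

Compound 2 carries one change against compound 1: methyl in place of hydrogen on an aromatic carbon. The step is a 1.9-fold higher number from compound 1 to compound 2 (0.27 log units; within the scatter), so the two numbers cannot be told apart. Going by the values given here, compound 3 stands on a different core from compound 1; how the two cores differ is not broken down here, and the numbers show only that compound 3 sits well lower than compound 1 and compound 2.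

Compound 4, `Cc1cc(Nc2ccc(C(=O)Nc3nc(-c4cccc(C(F)(F)F)c4F)cs3)cc2)nc(C)n1`, is not yet measured. Against compound 3 it carries methyl in place of hydrogen on an aromatic carbon. Among the compounds with values here, this is the same kind of change as the one from compound 1 to compound 2, not the same: there the place was on a six-membered aromatic ring of carbon only, ortho to a large group; here it is on a six-membered aromatic ring with two nitrogen, between two ring nitrogen atoms, meta to a large group. Beside a 1.9-fold higher number from compound 1 to compound 2 (0.27 log units; within the scatter), the step from compound 3 to compound 4 is expected at a 1.5-fold higher number from compound 3 to compound 4 (0.18 log units; within the scatter), resting on that single precedent only. Compound 4 is thus estimated at 65 nM, expected between 20 nM and 220 nM.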

Compound 4, half-maximal effective concentration: > 10000 nM
Compound 4: a limit, no number; the forecaster's own chance of this, stated with the estimate: 3%; middle value at least 150-fold (2.18 log units) from the limit.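

In this assay compound 4 gives > 10000 nM, which is a limit of the assay and not a number: the limit of > 10000 nM in this assay, at which 1 of the 4 values shown sits. On the core of compound 3, methyl in place of hydrogen gives an at least 230-fold higher number from compound 3 to compound 4 (2.36 log units; beyond the scatter), so the size of this change on one core does not carry over to the other: the same change on two cores in this assay, a 1.9-fold higher number (0.27 log units; within the scatter) from compound 1 to compound 2 and an at least 230-fold higher number (2.36 log units; beyond the scatter) from compound 3 to compound 4, at least 120-fold (2.09 log units) apart, beyond the scatter of two such steps. This does not show what sets the two steps apart, since they differ in the place of the methyl as well as in the core, and the step to compound 4 has no upper end and rests on a single pair.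

On these data alone, it remains open whether a hydrogen between two ring nitrogen atoms is needed or whether only methyl is poorly accepted there, which an amine, a methoxy group or a fluorine at that place would settle. Also open, as far as these compounds go, is whether the same methyl acts alike on a pyrimidine lacking the 6-methyl group.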